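The source may report more compounds than this note shows. Statements on the series, on what has been measured and on what is new or still open speak of the compounds shown alone.

Three compounds built on one shared core differ only in the aromatic ring attached to the sulfonyl sulfur. In an assay on isolated protein for displacement of a labelled ligand from metabotropic glutamate receptor 5 (Homo sapiens), with a stated time of 60 min, tested at 1 uM (on this read-out lower numbers stand for less inhibition and higher numbers for more inhibition at the one concentration tested (going by the name of the read-out)), compound 1 `Cc1ccc(S(=O)(=O)c2cnc3cc(Cl)ccc3c2N2CCC(C)CC2)cc1F` gives 85%, compound 2 `CC1CCN(c2c(S(=O)(=O)c3ccccc3)cnc3cc(Cl)ccc23)CC1` gives 93%, and compound 3 `CC1CCN(c2c(S(=O)(=O)c3cc(F)cc(F)c3)cnc3cc(Cl)ccc23)CC1` gives 94%, the highest of the three numbers, although a number 1 percentage points higher from compound 2 to compound 3 (within the scatter) and a number 9 percentage points higher from compound 1 to compound 3 (within the scatter) both lie within the scatter. Compound 4 `CC1CCN(c2c(S(=O)(=O)c3ccc(Cl)cc3)cnc3cc(Cl)ccc23)CC1` has not yet been measured. It differs from compound 3 in one place: 4-chlorophenyl in place of 3,5-difluorophenyl on a sulfonyl sulfur. The two steps that altered this same ring, a number 8 percentage points higher from compound 1 to compound 2 (within the scatter) and a number 1 percentage points higher from compound 2 to compound 3 (within the scatter), stayed within the scatter, so no step beyond the scatter is expected in this assay. Compound 4 is therefore estimated at 91%, between 81% and 98%. That estimate means an expected step of a number 3 percentage points lower from compound 3 to compound 4 (within the scatter).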

Compound 4, a percentage reported as inhibition, at one concentration (the size of the read-out at that concentration, not a potency): 91%
Compound 4: the middle estimate sits on the measured number at the digits printed, and the stated range covers the measured number.
By their numbers in this assay, from the lowest: compounds 1, 4, 2 and 3 (each within the scatter of the next).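

In this assay chloro in place of hydrogen on an aromatic carbon gives a number 2 percentage points lower from compound 2 to compound 4 (within the scatter) while the swaps of whole rings give a number 3 percentage points lower from compound 3 to compound 4 (within the scatter) and a number 6 percentage points higher from compound 1 to compound 4 (within the scatter). So a ring carrying chlorine on the sulfonyl sulfur joins the fluorinated, methylated and bare rings, and the four compounds cannot be told apart at this one concentration. Nothing available bears on why these numbers stay so close. As far as these compounds go, it remains open whether an amine or a carboxylic acid on this ring would move the number beyond the scatter. A single-concentration percentage also leaves any potency differences among these compounds open.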